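Thiazolidine ring replaces the branched amino side chain

The compounds below may be only part of what the source reports. "The series", "measured", "known", "first", "only" and "open" are said of these compounds alone.

The series consists of acyl sulfamate adenosine analogues. Compound 1 `Nc1ncnc2c1ncn2[C@@H]1CO[C@H](COS(=O)(=O)NC(=O)[C@@H]2CCCN2)[C@@H](O)[C@H]1O` gives 750 nM in a functional assay on PBMC cells (Homo sapiens) for inhibition (on this read-out higher numbers stand for weaker inhibition and lower numbers for stronger inhibition), compound 3 `N=C(N)NCCC[C@H](N)C(=O)NS(=O)(=O)OC[C@H]1OC[C@@H](n2cnc3c(N)ncnc32)[C@H](O)[C@@H]1O` gives 600 nM, and compound 2 `CC[C@H](C)[C@H](N)C(=O)NS(=O)(=O)OC[C@H]1O[C@@H](n2cnc3c(N)ncnc32)[C@H](O)[C@@H]1O` gives 5600 nM. Compound 2 therefore stands highest of the three numbers: compound 1 and compound 3 both lie well beyond the scatter below it. Going by the values given here, the only single-point step among the measured compounds, a 1.3-fold lower number from compound 1 to compound 3 (0.10 log units; within the scatter), shows that exchanging one acyl group for another of quite different size left the read-out essentially unchanged.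

Compound 4 `Nc1ncnc2c1ncn2[C@@H]1O[C@H](COS(=O)(=O)NC(=O)[C@@H]2CSCN2)[C@@H](O)[C@H]1O` has not yet been measured. Relative to compound 2 the change is 1,3-thiazolidin-4-yl in place of 1-amino-2-methylbutyl on a carbonyl carbon. Among the compounds with values here, no measured step covers this exact exchange, so the expectation rests on what the values show: the two compounds bearing a cyclic or larger acyl group, compound 1 and compound 3, both sit far below compound 2, and the step between them was within the scatter. He therefore expects the number for compound 4 to fall, estimated as a 3.7-fold lower number from compound 2 to compound 4 (0.57 log units; beyond the scatter), landing nearer the numbers of compound 1 and compound 3 than to that of compound 2. His estimate for compound 4 in this assay is 1500 nM, with a range from 500 nM to 5000 nM.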

Compound 4, half-maximal inhibitory concentration: 550 nM
The estimate for compound 4 lay 2.7-fold (0.44 log units) above the measured number; the range from low to high includes it.
By their numbers in this assay, from the lowest: compounds 4, 3 and 1 (each within the scatter of the next); then compound 2.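

Going by these compounds alone, the step of a 10-fold lower number from compound 2 to compound 4 (1.01 log units; beyond the scatter) in this assay shows that the group on this carbonyl carbon, whose other neighbour is the amide-type nitrogen, can move the read-out well beyond the scatter; the only earlier step, taken between two other acyl groups, had stayed within it. It also shows that the open-chain 1-amino-2-methylbutyl group can be replaced by 1,3-thiazolidin-4-yl, a five-membered non-aromatic ring, with stronger inhibition on the same core, so this position does not need the branched chain for activity here. No measurement bears on why the number drops so far, and the size of the step stands without an explanation.

The single step changes several things at once, so the compounds shown leave open whether the ring itself or the sulfur in it accounts for the difference. A 1,3-oxazolidin-4-yl ring, with oxygen in place of the sulfur, and an open-chain 1-amino-3-(methylsulfanyl)propyl group on the same carbonyl carbon and core would begin to separate the two.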